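Compound 4: methyl in place of methoxy

The compounds below may be only part of what the source reports. "The series", "measured", "known", "first", "only" and "open" are said of these compounds alone.

In a functional assay on KG-1 cells (Homo sapiens) for cytotoxicity, read by luminescence and CellTiter-Glo, with a stated time of 3 days (a lower number here means a stronger inhibitor, a higher number a weaker inhibitor), compound 1 `N#Cc1ccc(NC(=O)c2cccc(Br)c2O)cc1` gives 3260 nM and compound 2 `N#Cc1cc(Cl)ccc1NC(=O)c1ccc2cccnc2c1O` gives 3540 nM as measured numbers. Compound 3 `COc1cccc(C(=O)Nc2ccc(C#N)cc2)c1O` is reported as > 10000 nM, which is a limit and not a number. Compound 3 therefore stands at the limit of > 10000 nM in this assay, at which 1 of the 3 values shown sits, and has no exact place on the scale.

Compound 4 `Cc1cccc(C(=O)Nc2ccc(C#N)cc2)c1O` carries methyl in place of methoxy on an aromatic carbon, ortho to a hydroxy group and meta to a large group (methyl in place of methoxy on an aromatic carbon). For the measured compounds named here, the one measured step at this carbon is methoxy in place of bromo, which shows an at least 3.0-fold higher number from compound 1 to compound 3 (0.48 log units; beyond the scatter) and is open-ended. Going by the values given here, no measured step involves methyl, so the evidence on size is thin. Compound 1 at 3260 nM shows that a number can be read in this assay with a different group on this carbon, so a move toward a lower number is expected, though only part of the way. The expected change is an at least 1.6-fold lower number from compound 3 to compound 4 (0.22 log units; that floor lies within the scatter) and it may stay within the scatter. A second result reported only as a limit remains possible. Compound 4 is estimated at 6000 nM, with an expected range from 2500 nM to 10000 nM.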

Compound 4, half-maximal inhibitory concentration: 8980 nM
Compound 4: the middle estimate sits 1.5-fold (0.18 log units) below what was measured; the measured number falls inside the stated range.
By their numbers in this assay, from the lowest: compounds 1 and 2 (each within the scatter of the next); then compound 4. At a limit, above all of these: compound 3.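

On the carbon ortho to a hydroxy group, methyl in place of bromo gives a step with exact numbers at both ends in this assay, with a 2.8-fold higher number from compound 1 to compound 4 (0.44 log units; beyond the scatter), whereas the earlier step from bromo to methoxy was open-ended. Methyl in place of methoxy gives an at least 1.1-fold lower number from compound 3 to compound 4 (0.04 log units; that floor lies within the scatter), so this step fixes only a floor for the change, and its true size cannot be read from these two compounds. Compound 3 remains a limit of the assay and not a number, and this is what keeps the size of that step open: the limit of > 10000 nM in this assay, at which 1 of the 4 values shown sits.

The compounds shown leave open how an amine, a carboxylic acid, chloro or a longer chain such as ethyl would read on this carbon, and so whether the number follows any simple order across groups. They also leave open whether the step from bromo to methyl carries over to the core of compound 2, which differs from the other compounds in more than one place and therefore offers no comparison in this series.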